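From ethoxy to butoxy in the antiproliferative series

The source may report more compounds than this note shows. Statements on the series, on what has been measured and on what is new or still open speak of the compounds shown alone.

Measured in a functional assay on Huh-7 cells (Homo sapiens) for antiproliferative activity, with a stated time of 48 h; on this read-out lower numbers stand for stronger inhibition and higher numbers for weaker inhibition:
- Compound 1 `CCOC(=O)c1ccc(-c2ccc(N(C)C)nn2)cc1` gives > 25000 nM (a limit)
- Compound 2 `CCOC(=O)c1ccc(-c2ccc(OCC)nn2)cc1` gives > 25000 nM (a limit)

Compound 2 has no numerical value on this read-out, only the limit of > 25000 nM shown for it. Compound 3 `CCCCOc1ccc(-c2ccc(C(=O)OCC)cc2)nn1` has not yet been measured. It carries butoxy where compound 2 carries ethoxy, and the difference is ethyl in place of hydrogen on a saturated chain carbon, two bonds along the chain from an oxygen on an aromatic ring. In words, ethyl replaces hydrogen on a saturated chain carbon, two bonds along the chain from an oxygen on an aromatic ring.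

Within the data shown here, only one measured step bears on this change: a step that the two limits leave unreadable from compound 1 to compound 2. Compound 1 and compound 2 both sit at the limit of > 25000 nM in this assay, at which 2 of the 2 values shown sit, so that step has no readable size. It offers no measured guide to the size or direction of the ethoxy to butoxy change in this assay, and no clear step beyond the scatter is expected. The expected step is a step that the limit leaves unreadable from compound 2 to compound 3, an estimate with little support. Compound 3 is expected to give about 30000 nM, with an estimated range from 10000 nM to 60000 nM.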

Compound 3, half-maximal inhibitory concentration: > 25000 nM
Compound 3: only a limit was reported; the forecaster's own chance of this, stated with the estimate: 70%; the middle value lies beyond the limit too.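

In this assay compound 3 gives > 25000 nM, which is a limit and not a number. No step can be read among compound 1, compound 2 and compound 3, since all three share one limit: the limit of > 25000 nM in this assay, at which 3 of the 3 values shown sit.

The compounds shown leave open how strongly any of them inhibits these cells, and whether butoxy differs from ethoxy on this read-out.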